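Iodo for isopropyl on the ester ring: one step, two references

A few compounds are considered here, and "the series" means these few. Any claim that something is new, unique, unknown or untested is made for them only; others in the source may bear on it.

Measured so far:
- compound 1, `CC(=O)Nc1ccc(S(=O)(=O)Oc2ccccc2I)cc1`: 27000 nM
- compound 2, `CC(C)c1ccccc1OS(=O)(=O)c1ccc(NC(=O)CCl)cc1`: 2900 nM

Of the compounds shown here, two have been measured in a functional assay on MCF7 cells (Homo sapiens) for antiproliferative activity, read by sulforhodamine B assay, with a stated time of 48 h; a lower number here means a stronger inhibitor, a higher number a weaker inhibitor. Compound 1 is the acetamide with an iodo-bearing ester ring, and in this assay compound 1 gives 27000 nM. Compound 2 carries a chloroacetamide and an isopropyl-bearing ester ring, and in this assay compound 2 gives 2900 nM. Compound 2 holds the lowest of the two numbers, and the gap to compound 1 lies beyond the scatter. Compound 1 and compound 2 differ in two places at once. Among the measured compounds shown here, no single step between them can be read.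

Compound 3, `O=C(CCl)Nc1ccc(S(=O)(=O)Oc2ccccc2I)cc1`, keeps the chloroacetamide of compound 2 and changes only the ester ring: iodo in place of isopropyl on an aromatic carbon. The same iodo ring appears in compound 1, where it accompanies the much higher number, but the acetamide in compound 1 is also different, so the iodo ring itself cannot be held responsible for that. The step in this assay from compound 2 to compound 3 is expected to be small, towards a somewhat higher number, as a 1.7-fold higher number from compound 2 to compound 3 (0.24 log units; within the scatter). Compound 3 is estimated at 5000 nM, with a range from 1500 nM to 20000 nM.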

Compound 3, half-maximal inhibitory concentration: 2500 nM
For compound 3 the middle estimate is 2.0-fold (0.30 log units) above the measured one; the range from low to high includes it.
By their numbers in this assay, from the lowest: compounds 3 and 2 (each within the scatter of the next); then compound 1.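

In this assay, putting iodo in place of isopropyl on an aromatic carbon, ortho to a large group, gives a 1.2-fold lower number from compound 2 to compound 3 (0.06 log units; within the scatter) and so leaves the two compounds indistinguishable, even though one iodine atom replaces three carbon atoms. With the chloroacetamide held fixed, this place on the ester ring therefore accepts either group without a readable change in this cell assay. Compound 3 also links the two earlier compounds through single changes, and chloro in place of hydrogen on a saturated chain carbon bound to a carbonyl carbon gives an 11-fold lower number from compound 1 to compound 3 (1.03 log units; beyond the scatter) as a large step that the first pair, differing in two places at once, could not isolate.

The compounds shown leave open how a methoxy group or an amine would read at the same place on the ester ring, and whether isopropyl and iodo would also match when paired with the plain acetamide. They also leave open whether bromo in place of chloro on the chain would keep the lower number. No measurement at hand accounts for either step.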